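Removing One Chloro From a Dichlorinated Purine Core

The source may report more compounds than this note shows. Statements on the series, on what has been measured and on what is new or still open speak of the compounds shown alone.

Measured so far:
Compound 1 `Nc1nc(Cl)c2ncn(Cc3ccc(CCl)cc3)c2n1`: 6920 nM
Compound 2 `ClCc1ccccc1Cn1cnc2nc(Cl)nc(Cl)c21`: 1340 nM

In a functional assay on BT-549 cells (Homo sapiens) for cytotoxicity, read by sulforhodamine B assay, with a stated time of 48 h (on this read-out higher numbers stand for weaker inhibition of growth and lower numbers for stronger inhibition of growth), compound 2 gives the lower of the two numbers; compound 1 gives a number that lies clearly above it, beyond the usual scatter. Compound 3 `ClCc1ccccc1Cn1cnc2ncnc(Cl)c21` differs from compound 2 in one place: hydrogen in place of chloro on an aromatic carbon. Among the measured compounds shown here, no measured pair shows this change on its own, so its size is unknown. The step from compound 2 to compound 3 is expected to be small to modest, toward weaker growth inhibition, at most a little beyond the scatter, as a 1.9-fold higher number from compound 2 to compound 3 (0.27 log units; within the scatter). Compound 3 is therefore estimated at 2500 nM, in a range from 800 nM to 8000 nM.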

Compound 3, concentration for 50% growth inhibition: 2450 nM
Beside the measured number, compound 3's estimate is 1.0-fold (0.01 log units) above it; the measured number falls inside the stated range.
By their numbers in this assay, from the lowest: compounds 2 and 3 (each within the scatter of the next); then compound 1.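

Replacing the chloro with hydrogen on this aromatic carbon, between two ring nitrogen atoms, gives a 1.8-fold higher number from compound 2 to compound 3 (0.26 log units; within the scatter) and so leaves no difference that can be told apart in this assay. This chloro is therefore not needed to keep growth inhibition in this range when the rest of compound 2 stays unchanged. Nothing available explains this result.

Going by these compounds, what a methyl or methoxy group on this carbon would do remains open. So does the effect of changing the remaining chloro, which sits meta to this position.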